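Compound 2 to compound 4: acetyl for trifluoromethyl

This account rests on a few compounds, and the source may have more. Where it says the series, first, only, none or still open, it means among the compounds named here.

In a functional assay on HepG2 cells (Homo sapiens) for cytotoxicity, read by sulforhodamine B assay, with a stated time of 24 h (a higher number here means a weaker inhibitor, a lower number a stronger inhibitor), compound 1 (`N=c1oc2ccccc2cc1C(=O)N/N=C1\C(=O)Nc2ccc(S(=O)(=O)N3CCOCC3)cc21`) gives 7820 nM and compound 3 (`COc1ccc(-c2c(C#N)c(N)n(/N=C3\C(=O)Nc4ccc(S(=O)(=O)N5CCOCC5)cc43)c(=O)c2C#N)cc1`) gives 15000 nM in the same read-out. Compound 2 (`O=C1Nc2ccc(S(=O)(=O)N3CCOCC3)cc2/C1=N/c1cccc(C(F)(F)F)c1`) gives 14300 nM and lies within the scatter of both, so these three cannot be ranked. Compound 4 (`CC(=O)c1cccc(/N=C2\C(=O)Nc3ccc(S(=O)(=O)N4CCOCC4)cc32)c1`) has acetyl in place of trifluoromethyl on an aromatic carbon and is otherwise identical to compound 2. Among the measured compounds shown here, no measured pair differs in one place, so only the narrow spread of these three values guides the expectation. No step beyond the scatter is expected, and no direction can be argued: the estimated 1.2-fold lower number from compound 2 to compound 4 (0.08 log units; within the scatter) is small. The expected value for compound 4 is 12000 nM (estimated range 5000 nM to 30000 nM).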

Compound 4, half-maximal inhibitory concentration: 28600 nM
Compound 4: middle estimate off by 2.4-fold (0.38 log units), on the low side; the range from low to high includes it.
By their numbers in this assay, from the lowest: compounds 1, 2, 3 and 4 (each within the scatter of the next, the first and the last beyond it).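

In this assay, among the compounds shown here, the exchange of trifluoromethyl for acetyl, meta to a large group, gives a 2.0-fold higher number from compound 2 to compound 4 (0.30 log units; within the scatter) and so provides the only single-place comparison. At this position, a group with one hydrogen-bond acceptor and one with none therefore cannot be told apart in this read-out. No measurement is available that bears on this result. Going by these compounds, whether an amine or a carboxylic acid at this position would give a step beyond the scatter remains open. So does whether a longer chain would.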